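The source may report more compounds than this note shows. Statements on the series, on what has been measured and on what is new or still open speak of the compounds shown alone.

Series notes. Compound 1 `CCOc1ccccc1-c1ccc(-c2nc3cnccc3c(NC(C)C(=O)O)c2C#N)cc1`, compound 2 `CC[C@@H](Nc1c(C#N)c(-c2ccc(-c3cccc(C)c3F)cc2)nc2cnccc12)C(N)=O` and compound 3 `CC(C)(CC(N)=O)c1c(C#N)c(-c2ccc(Br)cc2)nc2cnccc12` share one core and have each been run in a physicochemical assay for lipophilicity, read by HPLC, at pH 7.5; a higher number here means a more lipophilic compound, a lower number a more polar compound. In this assay compound 1 gives 2.1, compound 3 gives 2.1 and compound 2 gives 3. Compound 2 stands highest of the three, its gap to compound 1 and its gap to compound 3 both lying beyond the scatter; compound 1 and compound 3 return the same number.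

Compound 4 `CC[C@@H](Nc1c(C#N)c(-c2ccc(-c3ccccc3CO)cc2)nc2cnccc12)C(N)=O` awaits measurement in this assay. It differs from compound 2 in one place: 2-(hydroxymethyl)phenyl in place of 2-fluoro-3-methylphenyl on an aromatic carbon. The entering group brings one hydrogen-bond donor and one hydrogen-bond acceptor where the leaving group brings none. The value for compound 4 is expected to sit lower than that of compound 2, by more than the scatter. The step expected from compound 2 to compound 4 is a number 1.20 log units lower from compound 2 to compound 4 (beyond the scatter). Compound 4 is estimated at 1.8, between 1.3 and 2.3.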

Compound 4, distribution coefficient: 2.1
Compound 4: middle estimate off by 0.30 log units, on the low side; the range from low to high includes it.
By their numbers in this assay, from the lowest: compounds 1, 3 and 4 (each within the scatter of the next); then compound 2.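

Swapping 2-fluoro-3-methylphenyl for 2-(hydroxymethyl)phenyl, on an aromatic carbon para to a large group, gives a number 0.90 log units lower from compound 2 to compound 4 (beyond the scatter) in this assay. Among these compounds, compounds 1, 2 and 3 differ from one another in more than one place, so this pair is the first reading of this position alone. The size of the step has no measured explanation here.

Going by these compounds, it remains open how an aminomethyl or carboxylic acid group on this ring, or a longer hydroxyalkyl chain, would read in this assay. On these data alone, whether the step carries over to other side chains on the shared core also remains open.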